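A few compounds are considered here, and "the series" means these few. Any claim that something is new, unique, unknown or untested is made for them only; others in the source may bear on it.

The measured compounds in a functional assay on BeWo cells (Homo sapiens) for cytotoxicity, read by MTT assay, with a stated time of 72 h; on this read-out lower numbers stand for stronger inhibition and higher numbers for weaker inhibition: compound 1 `Clc1ccccc1-c1nnc2nnc(N3CCCC3)nn12` gives 2990 nM. Compound 2 `Fc1ccc(-c2nnc3nnc(N4CCCC4)n3n2)cc1` reaches only the limit of > 100000 nM. Compound 3 `CCc1nnc2nnc(N3CCCC3)nn12` gives 5020 nM.

Compound 3 therefore holds the higher of the two numbers obtained, though compound 1 sits within the scatter of it, as seen in a 1.7-fold higher number from compound 1 to compound 3 (0.23 log units; within the scatter). Compound 4 `C1CCC(c2nnc3nnc(N4CCCC4)nn23)CC1` differs from compound 3 by cyclohexyl in place of ethyl on an aromatic carbon. Going by the values given here, the single measured step at this aromatic carbon, a 1.7-fold higher number from compound 1 to compound 3 (0.23 log units; within the scatter), stayed within the scatter, while compound 2 sits at a limit (the limit of > 100000 nM in this assay, at which 1 of the 3 values shown sits). Among the compounds with values here, no measured step involves a cyclohexyl, so no change beyond the scatter is expected, the estimated step being a 1.4-fold lower number from compound 3 to compound 4 (0.16 log units; within the scatter). Compound 4 is estimated at 3500 nM, within a range from 700 nM to 20000 nM.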

Compound 4, half-maximal inhibitory concentration: 22000 nM
The estimate for compound 4 lay 6.3-fold (0.80 log units) below the measured number; measured number above the stated range.
By their numbers in this assay, from the lowest: compounds 1 and 3 (each within the scatter of the next); then compound 4. At a limit, above all of these: compound 2.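

Going by these compounds alone, replacing the group on this aromatic carbon with cyclohexyl brought a 4.4-fold higher number from compound 3 to compound 4 (0.64 log units; beyond the scatter) and also a 7.4-fold higher number from compound 1 to compound 4 (0.87 log units; beyond the scatter) in this series, so the group here can move the number beyond the scatter, which the one earlier step at this position did not show. Nothing given here accounts for this rise. The compounds shown leave open whether an open chain such as butyl would follow ethyl or cyclohexyl, and how a ring carrying an amine, such as piperidine, would read at this carbon.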